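Methoxy in Place of Chloro in a Cytotoxic Triazole Series

This account rests on a few compounds, and the source may have more. Where it says the series, first, only, none or still open, it means among the compounds named here.

Compound 1, `C=C1C[C@]23C[C@@]1(O)CC[C@H]2c1ccc(O)c(C)c1[C@@H]3Cn1cc(-c2ccccn2)nn1`, in a functional assay on HL-60 cells (Homo sapiens) for cytotoxicity, read by MTT assay, with a stated time of 4 days; on this read-out lower numbers stand for stronger inhibition and higher numbers for weaker inhibition: > 20000 nM, a limit of the assay.
Compound 2, `C=C1C[C@]23C[C@@]1(O)CC[C@H]2c1ccc(OS(=O)(=O)c2ccc(C)cc2)c(C)c1[C@@H]3Cn1cc(-c2ccc(Cl)cc2)nn1`, in this assay: > 20000 nM, a limit of the assay.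
Compound 3, `Cc1ccc(S(=O)(=O)Oc2ccc3c(c2C)[C@H](Cn2cc(-c4ccccc4)nn2)[C@@]24CC(=O)[C@@](C)(CC[C@@H]32)C4)cc1`, in this assay: > 20000 nM, a limit of the assay.

All three measured compounds sit at the limit of > 20000 nM in this assay, at which 3 of the 3 values shown sit, so compound 2 stands nowhere apart from the others: its value is a limit, not a number, and the same holds for compound 1 and compound 3. Among the measured compounds shown here, no step between measured compounds can be drawn, and no order among them can be claimed.

The compound not yet measured, compound 4, `C=C1C[C@]23C[C@@]1(O)CC[C@H]2c1ccc(OS(=O)(=O)c2ccc(C)cc2)c(C)c1[C@@H]3Cn1cc(-c2ccc(OC)cc2)nn1`, differs from compound 2 in one place: methoxy in place of chloro on an aromatic carbon. Given that compound 2 sits at a limit, the change cannot be expected to move the read-out beyond the scatter in either direction; the most likely outcome is that compound 4 too is reported only as a limit. Compound 4 is therefore estimated at 30000 nM, with a range from 10000 nM to 100000 nM. That estimate corresponds to an expected step that the limit leaves unreadable from compound 2 to compound 4, none beyond the scatter.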

Compound 4, half-maximal inhibitory concentration: > 20000 nM
Compound 4: a limit, no number; the forecaster's own chance of this, stated with the estimate: 80%; the middle value is on the limit's open side.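

In this assay compound 4 gives > 20000 nM, a limit of the assay. Compound 2 is likewise reported only as a limit, so no step can be read between compound 2 and compound 4. The compounds shown leave open how methoxy compares with chloro here, and whether any compound of this series reaches a measurable value in this assay.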